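The source may hold more compounds than are shown below. What is called first, only, known or untested is meant among the compounds shown, and "the series" means these compounds.

Working notes on the series, three compounds measured so far. In a functional assay on HT-29 cells (Homo sapiens) for antiproliferative activity, read by MTT assay, with a stated time of 72 h (on this read-out higher numbers stand for weaker inhibition and lower numbers for stronger inhibition), compound 2 `CCNC(=O)c1cc(Oc2ccc(NC(=O)c3cc4cccnc4n(-c4ccccc4)c3=O)cc2)ccn1` gives 220 nM, compound 1 `CNC(=O)c1cc(Oc2ccc(NC(=O)c3cc4cccnc4n(-c4ccc(C(F)(F)F)cc4Cl)c3=O)cc2)ccn1` gives 3190 nM, and compound 3 `CCNC(=O)c1cc(Oc2ccc(NC(=O)c3cc4cccnc4n(-c4ccc(Br)cc4F)c3=O)cc2)ccn1` gives 2070 nM. Within the data shown here, compound 3 thus stands second highest of the three numbers; its nearest neighbour is compound 1, within the scatter of it, and the furthest is compound 2, a gap that is beyond the scatter and is the single step on record: a 9.4-fold higher number from compound 2 to compound 3 (0.97 log units; beyond the scatter).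

Compound 4 `CCNC(=O)c1cc(Oc2ccc(NC(=O)c3cc4cccnc4n(-c4ccc(C(F)(F)F)cc4Cl)c3=O)cc2)ccn1` is the next member, not yet measured in this assay. The change from compound 3 is 2-chloro-4-(trifluoromethyl)phenyl in place of 4-bromo-2-fluorophenyl on an aromatic nitrogen. Among the measured compounds shown here, no measured step covers this exchange directly. What bears on it is compound 1, which carries the same entering group together with a methylamide and gives 3190 nM, within the scatter of compound 3. On that basis the expected step is small, a 1.4-fold higher number from compound 3 to compound 4 (0.16 log units; within the scatter), with no direction claimed beyond the scatter. Compound 4 is therefore estimated at 3000 nM, in the range 1200 nM to 7500 nM.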

Compound 4, half-maximal inhibitory concentration: 4770 nM
The estimate for compound 4 lay 1.6-fold (0.20 log units) below the measured number; measured number inside the range.
By their numbers in this assay, from the lowest: compound 2; then compounds 3, 1 and 4 (each within the scatter of the next, the first and the last beyond it).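

In this assay, the position on the aromatic nitrogen also distinguishes between two substituted phenyl groups: 2-chloro-4-(trifluoromethyl)phenyl in place of 4-bromo-2-fluorophenyl gives a 2.3-fold higher number from compound 3 to compound 4 (0.36 log units; beyond the scatter) and the step is modest. Set against unsubstituted phenyl, the same entering group gives a 22-fold higher number from compound 2 to compound 4 (1.34 log units; beyond the scatter) as the largest step at this position so far, and both substituted phenyl groups in this ethylamide set stand beyond the scatter of phenyl. With this entering group in place, methyl in place of hydrogen on the amide chain gives a 1.5-fold higher number from compound 1 to compound 4 (0.17 log units; within the scatter) and thus no separation between the two amides.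

As far as these compounds go, whether an amine or a carboxylic acid on the phenyl ring, or a longer chain on the amide, would change these numbers remains open. Nothing on hand accounts for any of these steps.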